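Amide to anilino swap at the ring nitrogen

The compounds below may be only part of what the source reports. "The series", "measured", "known", "first", "only" and "open" are said of these compounds alone.

Within the data shown here, compound 2 `O=C(Nc1ncc(-c2cccc(Cl)c2)c(-c2ccccc2)n1)C1CCC1` holds the lower of the two numbers so far, though within the scatter of its neighbour; in an assay on CHO cells for displacement of a labelled ligand from adenosine receptor A1 (Homo sapiens), read by scintillation counting, with a stated time of 1 h, tested at 1 uM (on this read-out lower numbers stand for less inhibition and higher numbers for more inhibition at the one concentration tested (going by the name of the read-out)), compound 2 gives 52%. Compound 1 `CC(C)CC(=O)Nc1ncc(-c2cccc(Cl)c2)c(-c2ccccc2)n1` in this assay gives 56%; the step of a number 4 percentage points lower from compound 1 to compound 2 (within the scatter) stays within the scatter. Compound 3 `Clc1cccc(-c2cnc(Nc3ccccc3)nc2-c2ccccc2)c1` differs from compound 2 by phenyl in place of cyclobutylcarbonyl on a nitrogen on an aromatic ring. Among the measured compounds shown here, no measured step bears on this change: the only known step swaps cyclobutyl for isobutyl on a carbonyl carbon, so no direction can be drawn. The expected step of a number 7 percentage points lower from compound 2 to compound 3 (within the scatter) is therefore taken as none beyond the scatter, with wide uncertainty. Compound 3 is estimated at 45%, range 15% to 75%.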

Compound 3, a percentage reported as inhibition, at one concentration (the size of the read-out at that concentration, not a potency): 34%
Beside the measured number, compound 3's estimate is 11 percentage points above it; measured number inside the range.
By their numbers in this assay, from the lowest: compound 3; then compounds 2 and 1 (each within the scatter of the next).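

On a nitrogen on an aromatic ring, phenyl in place of cyclobutylcarbonyl gives a number 18 percentage points lower from compound 2 to compound 3 (beyond the scatter) in this assay, and phenyl in place of isobutylcarbonyl gives a number 22 percentage points lower from compound 1 to compound 3 (beyond the scatter). Exchanging the group on the carbonyl carbon had stayed within the scatter, whereas replacing the whole acyl group moves the number beyond it. No evidence at hand explains this change.

The compounds shown leave open whether losing the carbonyl or gaining the phenyl accounts for the step. A benzoyl group on that nitrogen would hold both together, and a free amine there would lack both.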